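Replacing isopropyl in a series sitting at its limit

The compounds below may be only part of what the source reports. "The series", "measured", "known", "first", "only" and "open" are said of these compounds alone.

Compound 1 (`CCC(C)(C)Cn1nc(-c2cccs2)c(O)c(C2=NS(=O)(=O)c3cc(NS(C)(=O)=O)ccc3N2)c1=O`): > 1000 nM (a limit)
Compound 2 (`CCC(C)CCn1nc(-c2cccs2)c(O)c(C2=NS(=O)(=O)c3cc(NS(C)(=O)=O)ccc3N2)c1=O`): > 1000 nM (a limit)
Compound 3 (`CC(C)Cn1nc(-c2cccs2)c(O)c(C2=NS(=O)(=O)c3cc(NS(C)(=O)=O)ccc3N2)c1=O`): > 1000 nM (a limit)

All three values come from an ADME assay on Huh-7 cells (Homo sapiens) for cytotoxicity, with a stated time of 72 h (on this read-out lower numbers stand for higher toxicity in this test and higher numbers for lower toxicity in this test), and none of them is a number. Compound 3 sits at the limit of > 1000 nM in this assay, at which 3 of the 3 values shown sit, and so has no measured value of its own to start from.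

Compound 4 (`CS(=O)(=O)Nc1ccc2c(c1)S(=O)(=O)N=C(c1c(O)c(-c3cccs3)nn(CC3(C(F)(F)F)CCC3)c1=O)N2`) differs from compound 3 in one place (1-(trifluoromethyl)cyclobutyl in place of isopropyl on a saturated chain carbon bound to an aromatic nitrogen). Here 1-(trifluoromethyl)cyclobutyl stands in place of isopropyl on a saturated chain carbon bound to an aromatic nitrogen.

Three measured steps change this same side chain (a step that the two limits leave unreadable from compound 1 to compound 2; a step that the two limits leave unreadable from compound 1 to compound 3; a step that the two limits leave unreadable from compound 2 to compound 3). None of them has a readable size, so they give no measure for the new change, although every side chain tried so far has stayed at the limit.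

On that basis, no step beyond the scatter and no direction is expected in this assay for the change (a step that the limit leaves unreadable from compound 3 to compound 4). For compound 4 the expected value is 2000 nM with an estimated range from 1000 nM to 10000 nM and a report of only a limit is the likeliest outcome.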

Compound 4, half-maximal cytotoxic concentration: > 1000 nM
Compound 4: no number, only a limit; the forecaster's own chance of this, stated with the estimate: 85%; the middle value does not contradict the limit.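

In this assay compound 4 gives > 1000 nM, which is a limit and not a number. The steps linking compound 4 with compound 1, compound 2 and compound 3 therefore cannot be read: the limit of > 1000 nM in this assay, at which 4 of the 4 values shown sit.

The compounds shown leave open whether these side chains differ at all in this read-out, since none has a measured number.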